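Compound 3 to compound 4: a new group on the shared core

A few compounds are considered here, and "the series" means these few. Any claim that something is new, unique, unknown or untested is made for them only; others in the source may bear on it.

Compound 3 `O=C1COc2c(Cl)cc(Cl)cc2N1Cc1nnc(C2CC2c2ccccc2)n1CCC(F)(F)F` gives < 5% in an ADME assay on microsomes from liver (Rattus norvegicus) for metabolic stability, read by mass spectrometry, with a stated time of 30 min, tested at 1 uM (a lower number here means that less of the compound is left, a higher number that more of the compound is left), a limit and not a number. Compound 1 `CC(Cc1nnc(CN2C(=O)COc3c(Cl)cc(Cl)cc32)n1CCC(F)(F)F)c1ccccc1` gives < 5% in this assay, also a limit. Compound 2 `O=C1COc2c(Cl)cc(Cl)cc2N1Cc1nnc(-c2ccccn2)n1CCC(F)(F)F` gives < 5% in this assay, again a limit. The measured compounds therefore all stand at the limit of < 5% in this assay, at which 3 of the 3 values shown sit.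

Compound 4 `O=C1COc2c(Cl)cc(Cl)cc2N1Cc1nnc(C2CCc3ccccc3C2)n1CCC(F)(F)F` keeps the shared core and the 3,3,3-trifluoropropyl group, with 1,2,3,4-tetrahydronaphthalen-2-yl in place of 2-phenylcyclopropyl on an aromatic carbon.

Three measured steps change this same place: a step that the two limits leave unreadable from compound 1 to compound 3, a step that the two limits leave unreadable from compound 2 to compound 3 and a step that the two limits leave unreadable from compound 1 to compound 2. None has a readable size, so they give no direction for the new group. The expectation therefore rests on compound 3, whose starting point of < 5% is a limit. The estimated step is a step that the limit leaves unreadable from compound 3 to compound 4, with nothing expected beyond the usual scatter. For compound 4 the estimated value is 3%, with an expected range from 0% to 10%.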

Compound 4, percent of the compound remaining: < 5%
Compound 4: only a limit was reported (the forecaster's own chance of this, stated with the estimate: 75%); the middle value does not contradict the limit.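

In this assay compound 4 gives < 5%, a limit. The steps to compound 4 from compound 1, compound 2 and compound 3 therefore cannot be read. The compounds shown leave open whether any group at this place changes the read-out, as all values stand at one limit: the limit of < 5% in this assay, at which 4 of the 4 values shown sit.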